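Selenium for sulfur on a shared isothiourea-like core

The compounds below may be only part of what the source reports. "The series", "measured", "known", "first", "only" and "open" are said of these compounds alone.

Measured compounds and their values:
Compound 1, `CS/C(=N\C(=O)c1ccno1)NC(=O)c1ccno1` — in a functional assay on PC-3 cells (Homo sapiens) for cytotoxicity, read by MTT assay, with a stated time of 72 h (on this read-out lower numbers stand for stronger inhibition of growth and higher numbers for weaker inhibition of growth), compound 1 gives 99200 nM.
Compound 2, `C[Se]/C(=N\C(=O)c1ccno1)NC(=O)c1ccno1` — in this assay compound 2 gives 90 nM.
Compound 3, `CS/C(=N\C(=O)c1cc(-c2ccccc2)nc2ccccc12)NC(=O)c1cc(-c2ccccc2)nc2ccccc12` — in this assay compound 3 gives 7480 nM.

Compound 1 and compound 2 share one core and differ in a single place: a group of 2 heavy atoms (1 carbon, 1 selenium; no ring) in place of a group of 2 heavy atoms (1 carbon, 1 sulfur; no ring), on a carbon with a double bond to nitrogen. This change produced a 1100-fold lower number from compound 1 to compound 2 (3.04 log units; beyond the scatter), a large step. Compound 3 carries a different core; the difference between the core of compound 1 and the core of compound 3 is not broken down here. In this assay compound 3 stands second highest of the three numbers, above compound 2 and below compound 1.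

Compound 4, `C[Se]/C(=N\C(=O)c1cc(-c2ccccc2)nc2ccccc12)NC(=O)c1cc(-c2ccccc2)nc2ccccc12`, has not yet been measured in this assay. It differs from compound 3 by a group of 2 heavy atoms (1 carbon, 1 selenium; no ring) in place of a group of 2 heavy atoms (1 carbon, 1 sulfur; no ring), on a carbon with a double bond to nitrogen, which is the same kind of change as that from compound 1 to compound 2, made on the other core; the place lines read the same word for word. Within the data shown here, the only precedent for this change is the large step from compound 1 to compound 2, so a step of similar direction is expected, though its size on the core of compound 3 is uncertain with only one example. Compound 4 is expected to give 30 nM in this assay, with a likely range from 4 nM to 250 nM, because a 1100-fold lower number from compound 1 to compound 2 (3.04 log units; beyond the scatter) shows how strongly the same change acted on the other core. This estimate means a step of a 250-fold lower number from compound 3 to compound 4 (2.40 log units; beyond the scatter) from compound 3 to compound 4.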

Compound 4, concentration for 50% growth inhibition: 3970 nM
Compound 4: middle estimate off by 130-fold (2.12 log units), on the low side, and the stated range ends below it.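

In this assay, the group with one carbon and one selenium took the place of methylsulfanyl on a carbon with a double bond to nitrogen and gave a 1.9-fold lower number from compound 3 to compound 4 (0.28 log units; within the scatter), so compound 3 and compound 4 cannot be told apart on this read-out. Set beside the earlier step, the same change did not carry the same size from one core to the other: the same change on two cores in this assay, a 1100-fold lower number (3.04 log units; beyond the scatter) from compound 1 to compound 2 and a 1.9-fold lower number (0.28 log units; within the scatter) from compound 3 to compound 4, 590-fold (2.77 log units) apart, beyond the scatter of two such steps This shows that the large step seen on the core of compound 1 cannot be treated as a fixed value of the change itself and transferred to another core in this series, but it does not show what in the two cores accounts for the gap, and two pairs give no rule for how the change would behave on any further core.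

The compounds shown leave open whether the step would stay large or vanish on cores intermediate between those of compound 1 and compound 3, for instance ones carrying an amine or a carboxylic acid on the acyl groups. They also leave open how a longer chain, such as ethyl or propyl in place of the methyl on the sulfur or selenium, would compare across the same two cores.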